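A few compounds are considered here, and "the series" means these few. Any claim that something is new, unique, unknown or untested is made for them only; others in the source may bear on it.

In a functional assay on A549 cells (Homo sapiens) for inhibition, read by MTT assay, with a stated time of 72 h (a higher number here means a weaker inhibitor, a lower number a stronger inhibitor), compound 1 `O=C(Nc1ccccc1)C1CCN(C/C=C/c2ccccc2)CC1` gives 69700 nM. Compound 2 `O=C(Nc1cccc(C(F)(F)F)c1)C1CCN(C/C=C/c2ccccc2)CC1`, which carries a trifluoromethyl group on the shared core, gives 15600 nM. Compound 3 `O=C(Nc1cccc(Cl)c1)C1CCN(C/C=C/c2ccccc2)CC1`, which carries a chloro group instead, gives 19100 nM. Compound 3 therefore stands well under compound 1 and level with compound 2 within the scatter. The remaining structure, compound 4 `O=C(Nc1cccc(Br)c1)C1CCN(C/C=C/c2ccccc2)CC1`, departs from compound 3 by a single exchange: bromo in place of chloro on an aromatic carbon, with the place otherwise unchanged. Within the data shown here, three measured steps bear on it. The first two, a 4.5-fold lower number from compound 1 to compound 2 (0.65 log units; beyond the scatter) and a 3.6-fold lower number from compound 1 to compound 3 (0.56 log units; beyond the scatter), are both modest, and they show what adding either group to the unsubstituted compound 1 did. Among the measured compounds shown here, the closest precedent is the exchange of one such group for another at the same place, a 1.2-fold higher number from compound 2 to compound 3 (0.09 log units; within the scatter), which stayed within the scatter. On that precedent, no step beyond the scatter is expected in this assay for the exchange of chloro for bromo. The expected step is a 1.1-fold lower number from compound 3 to compound 4 (0.05 log units; within the scatter). Compound 4 is estimated at 17000 nM, with an expected range of 9000 nM to 32000 nM.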

Compound 4, half-maximal inhibitory concentration: 16500 nM
Compound 4: middle estimate off by 1.0-fold (0.01 log units), on the high side; measured number inside the range.
By their numbers in this assay, from the lowest: compounds 2, 4 and 3 (each within the scatter of the next); then compound 1.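

In this assay, bromo on this aromatic carbon, meta to a large group, cannot be told apart from the two groups already placed there: the exchange for chloro gives a 1.2-fold lower number from compound 3 to compound 4 (0.06 log units; within the scatter), and the exchange for trifluoromethyl gives a 1.1-fold higher number from compound 2 to compound 4 (0.02 log units; within the scatter), so a third group now joins the level set by the first two. Bromo in place of hydrogen gives a 4.2-fold lower number from compound 1 to compound 4 (0.63 log units; beyond the scatter), a modest step of the same kind as those seen before, which leaves compound 1 as the only one of the four that stands apart, while the choice among chloro, bromo and trifluoromethyl shows no effect beyond the scatter. Nothing shown here offers an explanation for this level set of values.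

The compounds shown leave open whether the step away from compound 1 would also appear with a different kind of group at this place, such as an amine, a carboxylic acid, a methoxy group or a longer chain. They also leave open whether chloro, bromo or trifluoromethyl would give the same result on any other carbon of this ring.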